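Swapping a nitrophenyl amide for a cyclohexylmethyl amide

A few compounds are considered here, and "the series" means these few. Any claim that something is new, unique, unknown or untested is made for them only; others in the source may bear on it.

Measured compounds:
Compound 1, `COC(=O)[C@H](CCSC)NC(=O)c1ccc(CNCc2c[nH]cn2)cc1-c1ccccc1C`, gives 25 uM.
Compound 2, `N#Cc1ccc(Cn2cncc2CNc2ccc(C(=O)Nc3cccc([N+](=O)[O-])c3)c(-c3ccccc3)c2)cc1`, gives > 10 uM.

The read-out is a functional assay on NIH3T3 cells (Mus musculus); on this read-out higher numbers stand for an effect only at larger amounts of compound and lower numbers for an effect already at smaller amounts. Compound 1 sits at 25 uM in this assay. For compound 2 the result of > 10 uM is a limit of the assay, not a number; the point the limit of > 10 uM in this assay, at which 1 of the 2 values shown sits, marks where it rests. Compound 2 therefore stands at the weak end of what has been measured, without a value of its own.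

Compound 3, `N#Cc1ccc(Cn2cncc2CNc2ccc(C(=O)NCC3CCCCC3)c(-c3ccccc3)c2)cc1`, differs from compound 2 in one place: cyclohexylmethyl in place of 3-nitrophenyl on an amide-type nitrogen. Everything else in the two structures is the same. Going by the values given here, no pair of measured compounds shares this change, so there is no measured step to lean on; what is known of compound 2 is only a limit.

With that, only a modest move is expected. The step that the limit leaves unreadable from compound 2 to compound 3 is expected to be small, in either direction, and may not exceed the usual scatter. Compound 3 is estimated at 15 uM, with a range from 4 uM to 60 uM.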

Compound 3, concentration for half-maximal effect: > 10 uM
Compound 3 ended at the assay's limit; the forecaster's own chance of this, stated with the estimate: 55%; the middle value is on the limit's open side.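

In this assay, going by these compounds alone, compound 2 and compound 3 both rest at a limit of the assay, not at a number, so the swap from 3-nitrophenyl to cyclohexylmethyl gives no step that can be read: the limit of > 10 uM in this assay, at which 2 of the 3 values shown sit. Left open is how far either compound lies past that limit, and whether the swap changes the effect at all.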